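This account rests on a few compounds, and the source may have more. Where it says the series, first, only, none or still open, it means among the compounds named here.

Working notes on the series. In a functional assay on KYSE-450 cells (Homo sapiens) for inhibition, read by MTT assay, with a stated time of 48 h (on this read-out lower numbers stand for stronger inhibition and higher numbers for weaker inhibition), compound 1 (`COc1ccc(CN(C(=O)C(C)Br)c2cc(OC)c(OC)c(OC)c2)cc1O`) gives 160 nM and compound 2 (`C/C=C/C(=O)N(Cc1ccc(OC)c(N)c1)c1cc(OC)c(OC)c(OC)c1`) gives 310 nM while compound 3 (`C#CC(=O)N(Cc1ccc(OC)c(O)c1)c1cc(OC)c(OC)c(OC)c1`) gives 570 nM on the same read-out. Compound 3 lies within the scatter of compound 2 and stands apart from compound 1 by more than the scatter.

Next comes compound 4 (`COc1ccc(CN(C(=O)CO)c2cc(OC)c(OC)c(OC)c2)cc1O`), which carries hydroxymethyl in place of ethynyl on a carbonyl carbon. Within the data shown here, the only measured step at this place is a 3.6-fold higher number from compound 1 to compound 3 (0.55 log units; beyond the scatter) and neither of its groups is hydroxymethyl. Compound 2 differs from compound 3 in more than one place and offers no clean comparison. Among the measured compounds shown here, no measured compound carries hydroxymethyl on that carbonyl carbon, so the direction of any change rests on little evidence.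

For the measured compounds named here, with only that one modest step to go on, a change no larger than it is expected in this assay, with a slight lean toward a higher number and quite possibly nothing beyond the scatter. The expected change is a 1.2-fold higher number from compound 3 to compound 4 (0.09 log units; within the scatter) on this estimate. Compound 4 is estimated at 700 nM within a range from 200 nM to 2500 nM on this evidence.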

Compound 4, half-maximal inhibitory concentration: 370 nM
Beside the measured number, compound 4's estimate is 1.9-fold (0.28 log units) above it; the measured number falls inside the stated range.
By their numbers in this assay, from the lowest: compounds 1, 2, 4 and 3 (each within the scatter of the next, the first and the last beyond it).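

Across the series, a 1.5-fold lower number from compound 3 to compound 4 (0.19 log units; within the scatter) in this assay shows that on a carbonyl carbon whose other neighbour is the amide-type nitrogen, ethynyl, with no hydrogen-bond donor or acceptor, and hydroxymethyl, with one of each, cannot be told apart on this read-out. Among these compounds, the earlier compounds offered only one step at this place, whereas a 2.3-fold higher number from compound 1 to compound 4 (0.36 log units; beyond the scatter) now stands with a 3.6-fold higher number from compound 1 to compound 3 (0.55 log units; beyond the scatter) as a second step beyond the scatter, so 1-bromoethyl is set apart from two different groups rather than one, though both steps remain modest. Nothing available bears on the reason for any of these steps.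

Still open, from the compounds shown here alone, is whether the separation of compound 1 belongs to the bromine or to the branched carbon chain, a question that plain ethyl or isopropyl on the same carbonyl carbon would address directly. It also remains unclear how far this insensitivity to the ethynyl and hydroxymethyl exchange extends, for instance to aminomethyl, a carboxylic acid or a longer chain such as 2-hydroxyethyl at this place.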